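The source may hold more compounds than are shown below. What is called first, only, known or untested is meant among the compounds shown, and "the series" means these compounds.

In an assay on CHO cells for displacement of a labelled ligand from 5-hydroxytryptamine receptor 1D (Homo sapiens) (a lower number here means a stronger inhibitor, a higher number a weaker inhibitor), compound 3 `Fc1ccccc1CCC1(F)CCN(CCCc2c[nH]c3ccc(-n4cnnc4)cc23)CC1` gives 0.8 nM and stands second highest of the three numbers: compound 1 `FC1(Cc2ccccc2C(F)(F)F)CCN(CCCc2c[nH]c3ccc(-n4cnnc4)cc23)CC1` gives 0.3 nM and compound 2 `FC1(CCc2ccccc2)CCN(CCCc2c[nH]c3ccc(-n4cnnc4)cc23)CC1` gives 2 nM. The change to compound 4 `CC(CC1(F)CCN(CCCc2c[nH]c3ccc(-n4cnnc4)cc23)CC1)c1ccccc1` is 1-phenylethyl in place of 2-fluorobenzyl on a saturated chain carbon bound to a saturated ring carbon. Among the compounds with values here, the step that bears on it is a 2.5-fold lower number from compound 2 to compound 3 (0.40 log units; beyond the scatter), since the fluoro that entered there now leaves again; the methyl branch of the 1-phenylethyl group has no counterpart among the measured compounds. The other steps, a 6.7-fold higher number from compound 1 to compound 2 (0.82 log units; beyond the scatter) and a 2.7-fold higher number from compound 1 to compound 3 (0.43 log units; beyond the scatter), show how far this part of the molecule can move the number. Compound 4 is therefore expected to give 2.5 nM, with a range of 0.8 nM to 8 nM, a step of a 3.1-fold higher number from compound 3 to compound 4 (0.49 log units; beyond the scatter).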

Compound 4, half-maximal inhibitory concentration: 0.6 nM
For compound 4 the middle estimate is 4.2-fold (0.62 log units) above the measured one; the measured number lies below the stated range.
By their numbers in this assay, from the lowest: compounds 1, 4 and 3 (each within the scatter of the next, the first and the last beyond it); then compound 2.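

In this assay the added methyl, on a saturated chain carbon bound to an aromatic carbon and a saturated chain carbon, lowers the number without any fluoro on the phenyl ring (a 3.3-fold lower number from compound 2 to compound 4 (0.52 log units; beyond the scatter)). The 1-phenylethyl group cannot be told apart from 2-fluorobenzyl (a 1.3-fold lower number from compound 3 to compound 4 (0.12 log units; within the scatter)) or from 2-(trifluoromethyl)phenyl (a 2.0-fold higher number from compound 1 to compound 4 (0.30 log units; within the scatter)). Nothing available explains these steps. Still open, from the compounds shown here alone, is whether an ethyl or a hydroxyl on that chain carbon would give a similar number. Also open, going by these compounds, is how a fluoro on the phenyl ring of compound 4 would change it.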